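A few compounds are considered here, and "the series" means these few. Any claim that something is new, unique, unknown or untested is made for them only; others in the source may bear on it.

Compound 2 `N#C/C(=C\c1cc(O)c(O)c([N+](=O)[O-])c1)C(=O)Nc1ccccc1Cl` is an acrylonitrile amide bearing a nitro-substituted catechol; in a functional assay on KB cells (Homo sapiens) for antiproliferative activity, read by MTT assay (a higher number here means a weaker inhibitor, a lower number a stronger inhibitor), compound 2 gives 37.4 ug/mL, the higher of the two numbers available, while its closest neighbour, compound 1 `COc1ccc(NC(=O)/C(C#N)=C/c2cc(O)c(O)c([N+](=O)[O-])c2)cc1`, gives 29.2 ug/mL in this assay. Among the compounds with values here, the only measured step, a 1.3-fold higher number from compound 1 to compound 2 (0.11 log units; within the scatter), exchanges one aromatic amine substituent for another and stays inside the usual scatter. Compound 3 `N#C/C(=C\c1cc(O)c(O)c([N+](=O)[O-])c1)C(=O)N1CCOCC1` departs from compound 2 by a different kind of change: morpholin-4-yl in place of (2-chlorophenyl)amino on a carbonyl carbon. Within the data shown here, no measured step covers the loss of an aromatic amine in favour of a saturated cyclic amine, so the single available step gives only a weak guide, and it suggests that changes at this amide position move the number little. The expectation for compound 3 in this assay is therefore a step of a 1.2-fold higher number from compound 2 to compound 3 (0.08 log units; within the scatter) of modest size, estimated at 45 ug/mL with a range from 15 ug/mL to 130 ug/mL.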

Compound 3, half-maximal inhibitory concentration: > 100 ug/mL
Compound 3 gave a limit, no number; the forecaster's own chance of this, stated with the estimate: 10%; at least 2.2-fold (0.34 log units) between middle value and limit.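

In this assay, morpholin-4-yl in place of (2-chlorophenyl)amino on a carbonyl carbon gives an at least 2.6-fold higher number from compound 2 to compound 3 (0.42 log units; beyond the scatter), so this position does respond to at least one kind of change. The earlier step, a 1.3-fold higher number from compound 1 to compound 2 (0.11 log units; within the scatter), swapped one substituted phenyl ring on the amide nitrogen for another and could not show this. For compound 3 the reading is a limit, not a number, so the step has a lower bound but no known full size: the limit of > 100 ug/mL in this assay, at which 1 of the 3 values shown sits.

The change removes the aromatic ring and the amide hydrogen together, and the compounds shown cannot separate the two. As far as these compounds go, a cyclohexylamino group on the same carbonyl carbon would keep the amide hydrogen without the aromatic ring, and how it would read in this assay remains open.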